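Aryl replacement at the shared core: notes on compound 4

The source may hold more compounds than are shown below. What is called first, only, known or untested is meant among the compounds shown, and "the series" means these compounds.

compound 1 `N#Cc1ccc(-c2cc(COC(Cc3cn(C4CCN(Cc5ccc([N+](=O)[O-])cc5)CC4)nn3)c3ccc(Br)cc3)on2)cc1` — 3000 nM
compound 2 `O=[N+]([O-])c1ccc(CN2CCC(n3cc(CC(OCc4cc(-c5cccc(Br)c5)no4)c4ccc(Br)cc4)nn3)CC2)cc1` — 6000 nM
compound 3 `O=[N+]([O-])c1ccc(CN2CCC(n3cc(CC(OCc4cc(-c5ccccc5F)no4)c4ccc(Br)cc4)nn3)CC2)cc1` — 8000 nM

In a functional assay on MCF7 cells (Homo sapiens) for cytotoxicity, with a stated time of 48 h (a higher number here means a weaker inhibitor, a lower number a stronger inhibitor), compound 1 has the lowest of the three numbers; the step of a 2.0-fold higher number from compound 1 to compound 2 (0.30 log units; within the scatter) stays within the scatter, while a 2.7-fold higher number from compound 1 to compound 3 (0.43 log units; beyond the scatter) is a modest step beyond it. Compound 4 `COc1ccccc1-c1cc(COC(Cc2cn(C3CCN(Cc4ccc([N+](=O)[O-])cc4)CC3)nn2)c2ccc(Br)cc2)on1` is not yet measured. It differs from compound 1 as follows: 2-methoxyphenyl in place of 4-cyanophenyl on an aromatic carbon. Both aryl swaps measured so far moved the number up from compound 1, and the pair of other aryls, a 1.3-fold higher number from compound 2 to compound 3 (0.12 log units; within the scatter), are close to each other. A comparable upward step is therefore expected, a 2.3-fold higher number from compound 1 to compound 4 (0.37 log units; beyond the scatter), though a number within the scatter of compound 1 cannot be excluded. The estimate for compound 4 is 7000 nM, in the range 3000 nM to 16000 nM.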

Compound 4, half-maximal inhibitory concentration: 3000 nM
Compound 4: middle estimate off by 2.3-fold (0.37 log units), on the high side, within the range that was stated.
By their numbers in this assay, from the lowest: compounds 1, 4, 2 and 3 (each within the scatter of the next, the first and the last beyond it).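

With no change at the digits printed from compound 1 to compound 4 (within the scatter) in this assay the 2-methoxyphenyl stands level with 4-cyanophenyl, so replacing 4-cyanophenyl at this position does not by itself raise the number. With a 2.7-fold lower number from compound 3 to compound 4 (0.43 log units; beyond the scatter) as a modest step, the choice of methoxy or fluoro on the aryl does register here. With a 2.0-fold lower number from compound 2 to compound 4 (0.30 log units; within the scatter) the 2-methoxyphenyl and 3-bromophenyl remain unseparated.

From the compounds shown here alone, how a basic amine or a carboxylic acid on this aryl would read remains open. No evidence at hand accounts for these differences between the aryl groups.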